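A few compounds are considered here, and "the series" means these few. Any claim that something is new, unique, unknown or untested is made for them only; others in the source may bear on it.

Working notes on the series. In an ADME assay on microsomes from liver (Homo sapiens) for metabolic stability, read by LC-MS, with a stated time of 30 min, tested at 1 uM (on this read-out lower numbers stand for slow clearance and higher numbers for fast clearance), compound 1 (`Fc1ccc(-c2ccc3nnc(Cc4ccc5ncccc5c4)n3n2)cc1F`) gives 13.4 mL.min-1.g-1 and compound 2 (`C[C@@H](c1ccc2ncccc2c1)c1nnc2ccc(-c3cccc(C#N)c3)nn12`) gives 17.9 mL.min-1.g-1 and these two numbers lie within the usual scatter of each other, so they cannot be ranked. Compound 3 (`Nc1cnc2nnn(Cc3ccc4ncccc4c3)c2n1`) stands at < 7.6 mL.min-1.g-1 in this assay and this entry is a limit of the assay, not a number.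

The next step starts from compound 2. Compound 4 (`C[C@@H](c1ccc2ncccc2c1)c1nnc2ccc(-c3ccccc3C#N)nn12`) carries 2-cyanophenyl in place of 3-cyanophenyl on an aromatic carbon and is otherwise unchanged. The two groups hold the same atoms, joined differently.

For the measured compounds named here, no measured pair differs in one place only, so nothing measured gives the size of such a change. With no guide to size or direction, the expectation in this assay is for no step beyond the scatter. The anchor for that expectation is compound 2 at 17.9 mL.min-1.g-1 and a wide margin stays in place around it. The expected step is a 1.1-fold lower number from compound 2 to compound 4 (0.05 log units; within the scatter) and this estimate remains inside the scatter. For compound 4 the estimated value is 16 mL.min-1.g-1 with an expected range from 8.5 mL.min-1.g-1 to 30 mL.min-1.g-1 in this assay once measured.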

Compound 4, intrinsic clearance in microsomes in the Homo sapiens assay: 23.1 mL.min-1.g-1
Estimate against measurement, compound 4: 1.4-fold (0.16 log units) below; the range from low to high includes it.
By their numbers in the Homo sapiens assay, from the lowest: compounds 1, 2 and 4 (each within the scatter of the next). At a limit, below all of these: compound 3.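

In the Homo sapiens assay, 2-cyanophenyl in place of 3-cyanophenyl on this aromatic carbon gives a 1.3-fold higher number from compound 2 to compound 4 (0.11 log units; within the scatter), so this first pair differing in one place does not rank the two groups for clearance. In a physicochemical assay for solubility, measured as kinetic solubility, at pH 6.5 (a lower number here means a less soluble compound, a higher number a more soluble compound), compound 2 gives 32500 nM and compound 4 gives 213000 nM. In the physicochemical assay, the same change gives a 6.6-fold higher number from compound 2 to compound 4 (0.82 log units; beyond the scatter), which shows that this position can matter even when the atoms stay the same and only the way they are joined differs. The two read-outs therefore part ways for this one change, with clearance unresolved while solubility separates the two compounds: the measured solubility of compound 2, 32500 nM, and of compound 4, 213000 nM, a 6.6-fold higher number (0.82 log units; beyond the scatter)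

In the Homo sapiens assay compound 3 gives < 7.6 mL.min-1.g-1, which is a limit of the assay and not a number, and its core differs from that of compound 2, so it sets no guide for this position. The compounds shown leave open how a group other than a cyanophenyl, such as an amine or a carboxylic acid, would behave on this aromatic carbon, and whether the split between clearance and solubility would hold for such a group.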